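This account rests on a few compounds, and the source may have more. Where it says the series, first, only, none or still open, it means among the compounds named here.

Compound 1 `CC(=O)Oc1ccc(C(=O)Nc2cc3ccc(OCC4CCCN(C)C4)c(C)c3oc2=O)cc1CC=C(C)C` gives 740 nM in a functional assay on SK-BR-3 cells (Homo sapiens) for antiproliferative activity; on this read-out lower numbers stand for stronger inhibition and higher numbers for weaker inhibition. Compound 2 `CC(=O)Oc1ccc(C(=O)Nc2cc3ccc(OCCC4CCCCN4)c(C)c3oc2=O)cc1CC=C(C)C` gives 640 nM in this assay. Compound 3 `CCCN(CCC)CCCOc1ccc2cc(NC(=O)c3ccc(O)c(CC=C(C)C)c3)c(=O)oc2c1C` gives no number in this assay but only a limit, > 50000 nM.

Compound 3 thus stands at the edge of what this assay can report, at the limit of > 50000 nM in this assay, at which 1 of the 3 values shown sits, while compound 1 and compound 2 sit well inside the measurable range. Compound 4 `CC(C)=CCc1cc(C(=O)Nc2cc3ccc(OCCCNCCO)c(C)c3oc2=O)ccc1O` differs from compound 3 in one place: (2-hydroxyethyl)amino in place of dipropylamino on a saturated chain carbon, three bonds along the chain from an oxygen on an aromatic ring. The only measured step among these compounds, a 1.2-fold lower number from compound 1 to compound 2 (0.06 log units; within the scatter), also exchanges one amine-bearing group for another on the chain bound to the aromatic oxygen, and it stayed within the scatter. That step, however, runs between two compounds that both give numbers, whereas compound 3 gives only a limit, so how far the exchange can move a compound off that limit is not shown. Compound 4 is therefore expected to land near 20000 nM, from 2000 nM to 100000 nM, which would mean an estimated step of an at least 2.5-fold lower number from compound 3 to compound 4 (0.39 log units; beyond the scatter).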

Compound 4, half-maximal inhibitory concentration: 610 nM
For compound 4 the middle estimate is 33-fold (1.52 log units) above the measured one; the whole stated range lies above it.
By their numbers in this assay, from the lowest: compounds 4, 2 and 1 (each within the scatter of the next). At a limit, above all of these: compound 3.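

Among these compounds, at this place, on a saturated chain carbon, three bonds along the chain from an oxygen on an aromatic ring, the choice of amine group can matter far more than the one earlier step showed. In this assay, (2-hydroxyethyl)amino in place of dipropylamino gives an at least 81-fold lower number from compound 3 to compound 4 (1.91 log units; beyond the scatter), whereas the earlier exchange of one amine-bearing group for another gave a 1.2-fold lower number from compound 1 to compound 2 (0.06 log units; within the scatter). The true size of the new step stays unknown, since compound 3 gives only a limit of the assay: the limit of > 50000 nM in this assay, at which 1 of the 4 values shown sits.

The two compounds do not separate the loss of the propyl groups from the gain of the hydroxyl, as the exchange changes both at once. An ethylamino group, which has no hydroxyl, or a 3-hydroxypropylamino group on the same chain would bear on that question, and the compounds shown leave it open.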